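The source may report more compounds than this note shows. Statements on the series, on what has been measured and on what is new or still open speak of the compounds shown alone.

Compound 1 `C[C@H](NC(=O)Nc1ccc(C(F)(F)F)cc1)c1ccccc1`: 94%
Compound 2 `CCOC(=O)c1ccc(NC(=O)N[C@@H](C)c2ccccc2)cc1`: 97%
Compound 3 `C[C@H](NC(=O)Nc1ccc(F)cc1)c1ccccc1`: 97%

In an ADME assay on the whole organism with Oryza sativa as the target, tested at 1 uM (on this read-out higher numbers stand for a weaker effect at the one concentration tested and lower numbers for a stronger effect), compound 3 gives 97%; the step of no change at the digits printed from compound 2 to compound 3 (within the scatter) shows it level with compound 2, and the step of a number 3 percentage points higher from compound 1 to compound 3 (within the scatter) shows compound 1 sitting within the usual scatter of both, so the three measured numbers cannot be told apart.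

Compound 4 `C[C@H](NC(=O)Nc1ccc(Br)cc1)c1ccccc1` differs from compound 3 in one place: bromo in place of fluoro on an aromatic carbon. Among the measured compounds shown here, two measured steps bear on this, since both also swap the group on the same aromatic carbon of compound 3: a number 3 percentage points higher from compound 1 to compound 3 (within the scatter) and no change at the digits printed from compound 2 to compound 3 (within the scatter). Each of these stayed within the scatter, even though the groups exchanged were quite different from one another in size and make-up. Exchanging fluoro for bromo is a further swap at that same place, so the expectation is no shift beyond the scatter in this assay, that is an expected step of a number 1 percentage points lower from compound 3 to compound 4 (within the scatter). Compound 4 is therefore estimated at 96%, within a range from 88% to 100%.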

Compound 4, a percentage reported as activity, at one concentration (the size of the read-out at that concentration, not a potency): 97%
For compound 4 the middle estimate is 1 percentage points below the measured one; measured number inside the range.
By their numbers in this assay, from the lowest: compounds 1, 2, 3 and 4 (each within the scatter of the next).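

In this assay, the step for bromo in place of fluoro is no change at the digits printed from compound 3 to compound 4 (within the scatter), the step for bromo in place of ethoxycarbonyl is no change at the digits printed from compound 2 to compound 4 (within the scatter), and the step for bromo in place of trifluoromethyl is a number 3 percentage points higher from compound 1 to compound 4 (within the scatter). Until now this aromatic carbon had carried only fluoro, trifluoromethyl and ethoxycarbonyl, and a bromine atom now joins them as a fourth group that cannot be told apart from the others on this read-out. Nothing available here explains why the four numbers stay so close together.

From the compounds shown here alone, it remains open whether an amine or a carboxylic acid on this same carbon would move the number beyond the scatter. The compounds shown also leave open whether a change elsewhere on the shared core would do so.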